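Weighing a Pyridine Swap on a Weak Oxidase Inhibitor

This account rests on a few compounds, and the source may have more. Where it says the series, first, only, none or still open, it means among the compounds named here.

Compound 3 `Clc1ccccc1/C=N/Nc1nc2ccccc2nc1Cc1ccccc1` gives 87000 nM in an assay on isolated protein for inhibition of Amine oxidase [flavin-containing] B (Homo sapiens), read by spectrophotometry (on this read-out higher numbers stand for weaker inhibition and lower numbers for stronger inhibition), the lowest number of the three measured compounds. Compound 1 `COc1ccccc1/C=N/Nc1nc2ccccc2nc1Cc1ccccc1` gives 790000 nM, and compound 2 `COc1ccc(/C=N/Nc2nc3ccccc3nc2Cc2ccccc2)cc1OC` gives 460000 nM. The steps to compound 3 were modest: a 9.1-fold lower number from compound 1 to compound 3 (0.96 log units; beyond the scatter) and a 5.3-fold lower number from compound 2 to compound 3 (0.72 log units; beyond the scatter), while a 1.7-fold lower number from compound 1 to compound 2 (0.23 log units; within the scatter) stayed within the scatter. Compound 4 `C/C(=N\Nc1nc2ccccc2nc1Cc1ccccc1)c1ccccn1` carries a group of 9 heavy atoms (7 carbon, 2 nitrogen; one six-membered aromatic ring with 1 hetero atom) in place of a group of 9 heavy atoms (7 carbon, 1 nitrogen, 1 chlorine; one six-membered aromatic ring of carbon only), on a nitrogen on an aromatic ring. Among the measured compounds shown here, no measured step touches this change; the earlier steps only show that moving away from a chloro-bearing ring toward oxygen-bearing rings raised the number. By analogy, a modest rise is expected, a 2.9-fold higher number from compound 3 to compound 4 (0.46 log units; beyond the scatter). Compound 4 is therefore estimated at 250000 nM, with a likely range from 50000 nM to 1000000 nM.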

Compound 4, half-maximal inhibitory concentration: 980000 nM
For compound 4 the middle estimate is 3.9-fold (0.59 log units) below the measured one; the measured number falls inside the stated range.
By their numbers in this assay, from the lowest: compound 3; then compounds 2, 1 and 4 (each within the scatter of the next, the first and the last beyond it).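

Replacing the chlorine-bearing carbon ring with a ring holding one hetero atom, on a nitrogen on an aromatic ring, gives an 11-fold higher number from compound 3 to compound 4 (1.05 log units; beyond the scatter). Among the compounds shown here, compound 4 thus lands within the scatter of compound 1, so a high number here does not need an oxygen-bearing ring, and compound 3 remains the only compound with a clearly lower number. Nothing measured on these compounds explains this shift.

As far as these compounds go, the whole group changes at once, so the share of each part of it stays open. From the compounds shown here alone, whether a bromo or fluoro group, or an unsubstituted phenyl ring, would keep the lower number of compound 3 also stays open.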